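Chloro to Fluoro at Two Different Ring Places

The compounds below may be only part of what the source reports. "The series", "measured", "known", "first", "only" and "open" are said of these compounds alone.

Three compounds built on one shared core were tested in a functional assay on A549 cells (Homo sapiens) for cytotoxicity, read by MTT assay, with a stated time of 48 h; on this read-out lower numbers stand for stronger inhibition and higher numbers for weaker inhibition. Compound 1 `O=C(O)CN1C(=O)/C(=C/c2nc3ccccc3n2Cc2ccc(F)cc2)SC1=S` gives 3570 nM, compound 2 `O=C(O)CN1C(=O)/C(=C/c2nc3ccccc3n2Cc2ccc(Cl)cc2)SC1=S` gives 17500 nM, and compound 3 `Cc1ccc(Cn2c(/C=C3\SC(=S)N(CC(=O)O)C3=O)nc3ccc(Cl)cc32)cc1` gives 9970 nM. Compound 2 and compound 1 differ by fluoro in place of chloro on an aromatic carbon, which produced a 4.9-fold lower number from compound 2 to compound 1 (0.69 log units; beyond the scatter). How the core of compound 3 differs from that of compound 2 is not broken down here; the two values lie within the scatter of each other.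

Compound 4 `Cc1ccc(Cn2c(/C=C3\SC(=S)N(CC(=O)O)C3=O)nc3ccc(F)cc32)cc1` has not yet been measured. It differs from compound 3 by fluoro in place of chloro on an aromatic carbon. This is the same kind of change as that between compound 2 and compound 1, but not the same: in the earlier pair the swap sits on an aromatic carbon of a six-membered aromatic ring of carbon only, para to a large group, whereas in compound 3 the ring is part of a fused or bridged system of two rings, meta to a fused ring and para to a fused ring. Because the earlier swap gave a 4.9-fold lower number from compound 2 to compound 1 (0.69 log units; beyond the scatter), a step in the same direction, though smaller given the different place, is expected, about a 2.0-fold lower number from compound 3 to compound 4 (0.30 log units; within the scatter). Compound 4 is therefore expected to give roughly 5000 nM in this assay, plausibly between 2000 nM and 15000 nM.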

Compound 4, half-maximal inhibitory concentration: 9640 nM
The estimate for compound 4 lay 1.9-fold (0.29 log units) below the measured number; the measured number falls inside the stated range.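

In this assay, fluoro in place of chloro on the fused ring system gave a 1.0-fold lower number from compound 3 to compound 4 (0.01 log units; within the scatter), so compound 3 and compound 4 cannot be told apart on this read-out. The swap therefore did not carry its size over from one core to the other: the same change on two cores in this assay, a 4.9-fold lower number (0.69 log units; beyond the scatter) from compound 2 to compound 1 and a 1.0-fold lower number (0.01 log units; within the scatter) from compound 3 to compound 4, 4.7-fold (0.68 log units) apart, beyond the scatter of two such steps This shows that, across these two pairs, the result of the swap depends on where it sits or on the core that carries it, but it does not show which of the two matters, since the pairs differ in both, and two pairs give no general rule for the series.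

The compounds shown leave open whether the larger step belongs to the ring place of compound 1 and compound 2 or to the rest of that core. They also leave open whether a bromo or a methoxy group at either ring place would follow the larger step or the one within the scatter.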